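Swapping One Aromatic Group in a Cell Toxicity Test

The source may hold more compounds than are shown below. What is called first, only, known or untested is meant among the compounds shown, and "the series" means these compounds.

Three related compounds have been measured in an ADME assay on MRC5 cells (Homo sapiens) for cytotoxicity, read by fluorescence and resazurin assay, with a stated time of 3 days (a higher number here means a weaker inhibitor, a lower number a stronger inhibitor), so far: compound 1 (`Cc1cn(C2CCN(Cc3cccc(Oc4ccccc4)n3)CC2)c(=O)[nH]c1=O`), compound 2 (`Cc1ccc(Oc2cccc(CN3CCC(n4cc(C)c(=O)[nH]c4=O)CC3)c2)cc1`) and compound 3 (`Cc1cn(C2CCN(Cc3cc(Oc4cccc(Cl)c4)ccn3)CC2)c(=O)[nH]c1=O`). Compound 1 gives > 64000 nM as a limit, not a number. Compound 2 gives > 64000 nM as a limit, not a number. Compound 3 gives > 64000 nM as a limit, not a number. Compound 2 therefore stands with the others, and the whole picture is the limit of > 64000 nM in this assay, at which 3 of the 3 values shown sit, with no true number among them.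

Compound 4 (`Cc1cn(C2CCN(Cc3cccc(Oc4ccc(F)c(F)c4)c3)CC2)c(=O)[nH]c1=O`) is the next to be read. It differs from compound 2 in one place, with 3,4-difluorophenyl in place of 4-methylphenyl on an oxygen on an aromatic ring. For the measured compounds named here, no measured pair of compounds shows what a single change does here, so the expectation is modest. In this assay a step no larger than the usual scatter is expected, in neither direction. This expectation rests on compound 2 and its limit of > 64000 nM as the closest comparison. The estimated step reads an at least 1.0-fold lower number from compound 2 to compound 4 (0.02 log units; that floor lies within the scatter) in that case. Compound 4 is estimated at 60000 nM with an expected range from 25000 nM to 64000 nM and a bare limit as the likeliest report.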

Compound 4, half-maximal inhibitory concentration: > 64000 nM
Compound 4: no number, only a limit; the forecaster's own chance of this, stated with the estimate: 75%; middle value at least 1.0-fold (0.02 log units) away from the limit.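

In this assay compound 4 gives > 64000 nM, a limit and not a number. Compound 2 also gives only a limit, so no step can be read between compound 2 and compound 4. The compounds shown leave open how 3,4-difluorophenyl and 4-methylphenyl compare, and what any single change does, for all of them share one reading: the limit of > 64000 nM in this assay, at which 4 of the 4 values shown sit.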